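Effect of an added chloro on metabolic stability

The compounds below may be only part of what the source reports. "The series", "measured", "known", "first", "only" and "open" are said of these compounds alone.

Compound 1 `COc1ccc(S(=O)(=O)/C=C/c2ccccn2)cc1` heads the first pair. In an ADME assay on microsomes from liver (Homo sapiens) for metabolic stability, read by LC-MS, using NADPH, with stated times of 5 min and 30 min, tested at 1 uM (on this read-out higher numbers stand for a more stable compound and lower numbers for a less stable compound), compound 1 gives 56%. Compound 2 `COc1ccc(S(=O)(=O)/C=C/c2ccc(Cl)cn2)cc1` carries chloro in place of hydrogen on an aromatic carbon and in this assay compound 2 gives 6%; the step is a number 50 percentage points lower from compound 1 to compound 2 (beyond the scatter). Compound 3 `COc1ccccc1S(=O)(=O)/C=C/c1cccnc1Cl` rests on another core; the difference between the two cores is not broken down here. In this assay compound 3 gives 77%, the highest of the three numbers. Compound 4 `COc1ccccc1S(=O)(=O)/C=C/c1ccc(Cl)nc1Cl` differs from compound 3 by chloro in place of hydrogen on an aromatic carbon, the same kind of change as from compound 1 to compound 2, but the chloro now sits next to the ring nitrogen and meta to a chloro group rather than two atoms from the ring nitrogen. Because compound 2 fell to 6% after the same kind of change, a large drop is expected, estimated as a number 52 percentage points lower from compound 3 to compound 4 (beyond the scatter). Compound 4 is estimated at 25%, expected between 8% and 50%.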

Compound 4, percent of the compound remaining: 18%
Compound 4: middle estimate off by 7 percentage points, on the high side; measured number inside the range.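

In this assay the added chloro again brings a large loss, with a number 59 percentage points lower from compound 3 to compound 4 (beyond the scatter), so the change carries over from the core of compound 1 to the core of compound 3. Within the data shown here, the two steps match in size: the same change on two cores in this assay, a number 50 percentage points lower (beyond the scatter) from compound 1 to compound 2 and a number 59 percentage points lower (beyond the scatter) from compound 3 to compound 4, 9 percentage points apart, within the scatter of two such steps This rests on only two cores, and the chloro of compound 4 sits next to the ring nitrogen, so the pairs neither separate the effect of core from that of placement nor show why the number falls.

Going by these compounds, it remains open whether the loss is tied to chloro or would also follow another group on that carbon, such as an amine or a nitrile. On these data alone, how the change behaves on further cores also remains open.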